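Pyridin-3-yl to 4-methylpiperazin-1-yl on a carbonyl carbon

This account rests on a few compounds, and the source may have more. Where it says the series, first, only, none or still open, it means among the compounds named here.

Measured so far in a functional assay on NIH3T3 cells (Mus musculus) for inhibition, read by neutral red uptake, with a stated time of 24 h; on this read-out higher numbers stand for an effect only at larger amounts of compound and lower numbers for an effect already at smaller amounts:
- compound 1 `CCN(CC)CCCC(C)NC(=O)OC1=C(c2cccc3ncccc23)Oc2cc3ccccc3cc2-n2cccc21` gives 6000 nM
- compound 2 `O=C(OC1=C(c2cccc3ncccc23)Oc2cc3ccccc3cc2-n2cccc21)c1cccnc1` gives 6000 nM
- compound 3 `CC(=O)OC1=C(c2cccc3ccccc23)Oc2cc3c(cc2-n2cccc21)OCCO3` gives 100 nM

Compound 2 shares the highest number of the three with compound 1, while compound 3 lies far lower. Compound 4 `CN1CCN(C(=O)OC2=C(c3cccc4ncccc34)Oc3cc4ccccc4cc3-n3cccc32)CC1` has not yet been measured. It differs from compound 2 by 4-methylpiperazin-1-yl in place of pyridin-3-yl on a carbonyl carbon and so carries 4-methylpiperazin-1-yl in place of pyridin-3-yl on a carbonyl carbon.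

Going by the values given here, one measured step bears directly on this change. It exchanged (4-(diethylamino)-1-methylbutyl)amino for pyridin-3-yl at that same carbonyl carbon and gave no change at the digits printed from compound 1 to compound 2 (within the scatter) in this series. Two very different groups at this place thus left the number where it was. Compound 3 differs from compound 2 in its core as well, so its value isolates no effect of the group on the carbonyl carbon. Among the compounds with values here, no measured compound carries 4-methylpiperazin-1-yl, which leaves the single step from compound 1 as the only guide and widens the uncertainty.

The expected outcome is no change at the digits printed from compound 2 to compound 4 (within the scatter) in this assay with no step beyond the scatter and no favoured direction. For compound 4 the estimate is 6000 nM with 2500 nM to 14000 nM as the expected range.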

Compound 4, half-maximal effective concentration: 450 nM
Beside the measured number, compound 4's estimate is 13-fold (1.12 log units) above it, outside the stated range (below it).
By their numbers in this assay, from the lowest: compound 3; then compound 4; then compounds 1 and 2 (each within the scatter of the next).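

The group on the carbonyl carbon turns out to matter in this assay: 4-methylpiperazin-1-yl in place of pyridin-3-yl gives a 13-fold lower number from compound 2 to compound 4 (1.12 log units; beyond the scatter) and the same group in place of (4-(diethylamino)-1-methylbutyl)amino gives a 13-fold lower number from compound 1 to compound 4 (1.12 log units; beyond the scatter) on the same core, so the flat step between the first two compounds did not mean that this place tolerates any group. Nitrogen on the carbonyl carbon cannot by itself go with the lower number, since compound 1 has it too and still stands level with compound 2, which has a ring carbon there; of these three groups, only the six-membered non-aromatic ring with two hetero atoms stands apart. Nothing measured here accounts for the shift, and no explanation can be offered for it.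

The compounds shown do not tell whether the methyl on the piperazine takes part, which piperazin-1-yl, morpholin-4-yl or piperidin-1-yl would settle, nor whether an open-chain dimethylamino group would do the same. On these data alone, it also remains open whether 4-methylpiperazin-1-yl would lower the number on the core of compound 3, which carries a methyl on its carbonyl carbon.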